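Solubility of a nitrophenyl series: one ring swap from compound 1

A few compounds are considered here, and "the series" means these few. Any claim that something is new, unique, unknown or untested is made for them only; others in the source may bear on it.

Compound 1 `O=C(O)c1ccc(C(=O)/C(=C\c2ccc(Br)c([N+](=O)[O-])c2)SCc2ccc(Br)cc2)cc1`: in a physicochemical assay for solubility (a higher number here means a more soluble compound, a lower number a less soluble compound), compound 1 gives < 1000 ug/mL, which is a limit of the assay rather than a number.
Compound 2 `O=C(O)c1ccc(C(=O)/C(=C\c2ccc(F)c([N+](=O)[O-])c2)SCc2ccc(C(F)(F)F)cc2)cc1`: in this assay compound 2 gives < 1000 ug/mL, again a limit.
Compound 3 `O=C(O)c1ccc(C(=O)/C(=C\c2ccc(Br)c([N+](=O)[O-])c2)SCc2ccc(Cl)cc2)cc1`: in this assay compound 3 gives < 1000 ug/mL, also a limit.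

Compound 1 therefore stands only at a limit in this assay, and the two other values shown are limits as well. For the measured compounds named here, the one measured step that differs in a single place, chloro in place of bromo on an aromatic carbon, is a step that the two limits leave unreadable from compound 1 to compound 3, so its size cannot be read. The shared position of all three values is the limit of < 1000 ug/mL in this assay, at which 3 of the 3 values shown sit.

Compound 4 `O=C(O)c1ccc(C(=O)/C(=C\c2cc([N+](=O)[O-])ccc2F)SCc2ccc(Br)cc2)cc1` differs from compound 1 in one place: 2-fluoro-5-nitrophenyl in place of 4-bromo-3-nitrophenyl on a double-bonded chain carbon bound to a double-bonded chain carbon. Going by the values given here, no measured step bears directly on this change, and the one step that exists is unreadable, so no direction can be drawn from the data. Compound 4 is expected to give 300 ug/mL in this assay, within 30 ug/mL to 1000 ug/mL. The expected step is a step that the limit leaves unreadable from compound 1 to compound 4, none beyond the scatter, and most likely compound 4 is again expected to be reported only at the limit.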

Compound 4, solubility: < 1000 ug/mL
Compound 4: only a limit was reported (the forecaster's own chance of this, stated with the estimate: 80%); the middle value does not contradict the limit.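

No new step can be read, since compound 1 and compound 4 are both reported only as limits, and all the values shown share one position: the limit of < 1000 ug/mL in this assay, at which 4 of the 4 values shown sit.

The compounds shown leave open where any of the four truly stands in this assay, and whether either single change moves it at all.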